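The source may report more compounds than this note shows. Statements on the series, on what has been measured and on what is new or still open speak of the compounds shown alone.

Series in a functional assay on Huh-5-2 cells (Homo sapiens), read by MTT assay; on this read-out higher numbers stand for lower toxicity in this test and lower numbers for higher toxicity in this test:
- Compound 1 `O=C(O)c1ccc2c(c1)nc(-c1ccc(OCc3ccccc3-c3ccc(Cl)cc3)cc1)n2C1CCCCC1`: 25000 nM
- Compound 2 `CC(=O)c1ccc(-c2ccc(Cl)cc2)c(COc2ccc(-c3nc4cc(C(=O)O)ccc4n3C3CCCCC3)cc2)c1`: 24000 nM
- Compound 3 `O=C(O)c1ccc(-c2ccc(Cl)cc2)c(COc2ccc(-c3nc4cc(C(=O)O)ccc4n3C3CCCCC3)cc2)c1`: > 50000 nM, a limit of the assay

Compound 3 has no number, only this limit. The next analogue, compound 4 `N#Cc1ccc(-c2ccc(Cl)cc2)c(COc2ccc(-c3nc4cc(C(=O)O)ccc4n3C3CCCCC3)cc2)c1`, has cyano in place of carboxy on an aromatic carbon, para to a 4-chlorophenyl group: cyano in place of carboxy on an aromatic carbon.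

Among the compounds with values here, three measured steps bear on this change. Adding acetyl at that carbon gave a 1.0-fold lower number from compound 1 to compound 2 (0.02 log units; within the scatter). Adding carboxy there gave an at least 2.0-fold higher number from compound 1 to compound 3 (0.30 log units; that floor lies within the scatter). Exchanging the acetyl for carboxy gave an at least 2.0-fold higher number from compound 2 to compound 3 (0.31 log units; beyond the scatter), the only one of the three that clearly exceeds the scatter, though it is only a floor.

Cyano also removes the carboxy, so a return towards compound 2, with its 24000 nM, is expected. A lower number than the limit of compound 3 is the likely direction. The expected change is an at least 1.9-fold lower number from compound 3 to compound 4 (0.28 log units; that floor lies within the scatter). The estimate for compound 4 is 26000 nM, with an expected range of 12000 nM to 50000 nM.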

Compound 4, half-maximal cytotoxic concentration: 23000 nM
Compound 4: the middle estimate sits 1.1-fold (0.05 log units) above what was measured; the range from low to high includes it.
By their numbers in this assay, from the lowest: compounds 4, 2 and 1 (each within the scatter of the next). At a limit, above all of these: compound 3.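

In this assay the change from carboxy to cyano, on the carbon para to a 4-chlorophenyl group, loses the high reading of compound 3 (an at least 2.1-fold lower number from compound 3 to compound 4 (0.33 log units; beyond the scatter)), so cyano joins acetyl among the groups that do not carry it. Cyano cannot be told apart from acetyl (a 1.0-fold lower number from compound 2 to compound 4 (0.02 log units; within the scatter)) or from hydrogen on this carbon (a 1.1-fold lower number from compound 1 to compound 4 (0.04 log units; within the scatter)), which leaves carboxy as the only group shown that stands apart at this position. The value of compound 3 is a limit and not a number, so the step to compound 4 is a floor only: the limit of > 50000 nM in this assay, at which 1 of the 4 values shown sits.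

As far as these compounds go, how far compound 3 truly lies from the other compounds stays open. Also open, from the compounds shown here alone, is whether an amine, a sulfonic acid or a tetrazole on this carbon would read like compound 3 or like compound 4.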